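Trimming an Alkyl Chain: Expected Effect on Growth Inhibition

The compounds below may be only part of what the source reports. "The series", "measured", "known", "first", "only" and "open" are said of these compounds alone.

Measured so far:
Compound 1 `CC(C)COC(=O)Nc1ccc([Se]C#N)cc1` gives 21600 nM in an ADME assay on 184B5 cells (Homo sapiens) for cytotoxicity, read by MTT assay, with a stated time of 72 h; a higher number here means a weaker inhibitor of growth, a lower number a stronger inhibitor of growth.
Compound 2 `CCCCCCOC(=O)Nc1ccc([Se]C#N)cc1` gives 20000 nM in this assay.

Compound 2 and compound 1 give numbers within the scatter of each other. Compound 3 `CCOC(=O)Nc1ccc([Se]C#N)cc1` differs from compound 2 by hydrogen in place of butyl on a saturated chain carbon, two bonds along the chain from an oxygen next to a carbonyl group. Among the compounds with values here, the one measured step that bears on this chain, a 1.1-fold lower number from compound 1 to compound 2 (0.03 log units; within the scatter), showed nothing beyond the scatter. A further shortening of the chain is therefore expected to give no step beyond the scatter in this assay. Compound 3 is estimated at 22000 nM, with a range of 11000 nM to 44000 nM, an expected step of a 1.1-fold higher number from compound 2 to compound 3 (0.04 log units; within the scatter).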

Compound 3, concentration for total growth inhibition: 18600 nM
Beside the measured number, compound 3's estimate is 1.2-fold (0.07 log units) above it, within the range that was stated.
By their numbers in this assay, from the lowest: compounds 3, 2 and 1 (each within the scatter of the next).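

Hydrogen in place of butyl, the same difference as hexyl to ethyl, gave a 1.1-fold lower number from compound 2 to compound 3 (0.03 log units; within the scatter) in this assay, and methyl in place of isopropyl gave a 1.2-fold lower number from compound 1 to compound 3 (0.06 log units; within the scatter). The ethyl chain of compound 3 thus extends the flat stretch at this position to a shorter chain than the earlier pair covered. No measurement offered here accounts for this flatness. Going by these compounds, whether an amine or a carboxylic acid on this chain, or a chain longer than hexyl, would give a step beyond the scatter remains open.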